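Cytotoxicity notes on a shared core: compound 2 to compound 3

A few compounds are considered here, and "the series" means these few. Any claim that something is new, unique, unknown or untested is made for them only; others in the source may bear on it.

Compound 1 `C=CCn1c(=O)/c(=C\c2ccccc2Cl)[nH]c(=O)/c1=C\c1ccccc1OC` in a functional assay on Huh-7 cells (Homo sapiens) for cytotoxicity, read by CCK-8 assay, with a stated time of 72 h (on this read-out higher numbers stand for weaker inhibition and lower numbers for stronger inhibition), gives 6400 nM. Compound 2 `C=CCn1c(=O)/c(=C\c2ccc(F)c(Br)c2)[nH]c(=O)/c1=C\c1ccccc1OC` in this assay is reported only as "not active" (no number reported), with no number attached, so compound 2 stands without a place on the scale of this read-out and its distance from compound 1 cannot be sized. Compound 3 `C=CCn1c(=O)/c(=C\c2ccc(C)cc2)[nH]c(=O)/c1=C\c1ccccc1OC` has not yet been measured in this assay. It differs from compound 2 by 4-methylphenyl in place of 3-bromo-4-fluorophenyl on a double-bonded chain carbon bound to an aromatic carbon. For the measured compounds named here, no measured step covers this change on the shared core, and with compound 2 lacking a number neither the direction nor the size of the step to compound 3 can be drawn from the data; no change beyond the usual scatter is claimed. Given compound 1 at 6400 nM and compound 2 without a number, compound 3 is expected to inhibit weakly, with a report carrying no number quite possible. For compound 3 the estimated half-maximal inhibitory concentration in this assay is 15000 nM, expected between 4000 nM and 60000 nM.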

Compound 3, half-maximal inhibitory concentration: "not active" (no number reported)
The entry for compound 3 holds no number, and the estimate cannot be compared.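

No new step can be read: compound 2 and compound 3 both stand in this assay as not active, with no number. The compounds shown leave open how far 4-methylphenyl and 3-bromo-4-fluorophenyl differ on the shared core. No evidence bears on this result.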